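Moving the Two Chlorines on the Cyclized Analogue

The source may report more compounds than this note shows. Statements on the series, on what has been measured and on what is new or still open speak of the compounds shown alone.

Measured compounds:
compound 1 `COc1cc(C(=O)N/N=C/c2ccc(F)c(F)c2)cc(OC)c1OC` gives 51.9% in a functional assay on BGC-823 cells (Homo sapiens) for antiproliferative activity, read by MTT assay, tested at 5 uM; on this read-out lower numbers stand for a weaker effect and higher numbers for a stronger effect at the one concentration tested
compound 2 `COc1cc(C2=NN(C(C)=O)C(c3c(Cl)cccc3Cl)O2)cc(OC)c1OC` gives 15.9% in this assay
compound 3 `COc1cc(C(=O)N/N=C/c2ccc(C(F)(F)F)cc2)cc(OC)c1OC` gives 56.3% in this assay

Among these three, compound 2 stands lowest in this assay, with compound 1 and compound 3 both well beyond the scatter above it, while the values of compound 1 and compound 3 lie within the scatter of each other. Compound 2 is the only one of the three that carries the acetylated five-membered ring rather than the open hydrazone, and that is where the untested compound 4 `COc1cc(C2=NN(C(C)=O)C(c3ccc(Cl)c(Cl)c3)O2)cc(OC)c1OC` belongs as well. The two have the same atoms, joined differently: 3,4-dichlorophenyl in place of 2,6-dichlorophenyl on a saturated ring carbon. The group that leaves is 2,6-dichlorophenyl and the group that enters is 3,4-dichlorophenyl, both sitting on the same saturated ring carbon. For the measured compounds named here, no measured pair shows what such a rearrangement does on this core, so the expectation rests on compound 2 alone. The step of a number 6.1 percentage points higher from compound 2 to compound 4 (within the scatter) is expected to be small, likely within the scatter. Compound 4 is estimated at 22%, in a range from 5% to 42%.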

Compound 4, a percentage reported as inhibition, at one concentration (the size of the read-out at that concentration, not a potency): 3.1%
The estimate for compound 4 lay 18.9 percentage points above the measured number; the measured number lies below the stated range.
By their numbers in this assay, from the lowest: compound 4; then compound 2; then compounds 1 and 3 (each within the scatter of the next).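

For the compounds shown here, the pair gives the first reading of this position: with the atoms unchanged, 3,4-dichlorophenyl in place of 2,6-dichlorophenyl on the saturated ring carbon gives a number 12.8 percentage points lower from compound 2 to compound 4 (beyond the scatter) in this assay. Going by these compounds alone, the placement of the two chlorines alone therefore moves the read-out on this core, and the step lies beyond the usual scatter, which the earlier compounds could not show. No measurement at hand accounts for this difference.

The compounds shown leave open how this ring carbon would respond to a phenyl ring bearing a single chlorine, a methoxy group or an amine, or to other placements of the two chlorines. They also leave open whether a propionyl group in place of the acetyl group would alter the outcome for either chlorine pattern.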